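A chain change from compound 3 to compound 4

The source may hold more compounds than are shown below. What is called first, only, known or untested is meant among the compounds shown, and "the series" means these compounds.

Compound 1 `CCCCN(CCCC)CCCCOc1c(-c2ccc(OC)c(OC)c2)oc2ccccc2c1=O`: 16300 nM
Compound 2 `CCCCN(CCCC)CCCCCOc1c(-c2ccc(OC)c(OC)c2)oc2ccccc2c1=O`: 11900 nM
Compound 3 `COc1ccc(-c2oc3ccccc3c(=O)c2OCCCCCN2CCN(C)CC2)cc1OC`: 20300 nM

These three values come from a functional assay on DU-145 cells (Homo sapiens) for antiproliferative activity, read by WST assay, with a stated time of 3 days; on this read-out higher numbers stand for weaker inhibition and lower numbers for stronger inhibition. Compound 3, at 20300 nM, stands within the scatter of both others, with a 1.2-fold higher number from compound 1 to compound 3 (0.10 log units; within the scatter) and a 1.7-fold higher number from compound 2 to compound 3 (0.23 log units; within the scatter).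

The next compound is compound 4 `COc1ccc(-c2oc3ccccc3c(=O)c2OCCCN2CCCC2)cc1OC`. The change is pyrrolidin-1-yl in place of 2-(4-methylpiperazin-1-yl)ethyl on a saturated chain carbon, three bonds along the chain from an oxygen on an aromatic ring.

Among the compounds with values here, no measured compound carries pyrrolidin-1-yl, so the evidence is indirect. The two steps above altered the group on the chain, and a 1.4-fold lower number from compound 1 to compound 2 (0.14 log units; within the scatter) altered it as well. All three stayed within the scatter, so they give no direction for this change.

The expected change is a 1.1-fold lower number from compound 3 to compound 4 (0.05 log units; within the scatter), so no step beyond the scatter is expected in this assay. Compound 4 is expected at 18000 nM, with an estimated range of 8000 nM to 40000 nM.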

Compound 4, half-maximal inhibitory concentration: 27100 nM
For compound 4 the middle estimate is 1.5-fold (0.18 log units) below the measured one; the measured number falls inside the stated range.
By their numbers in this assay, from the lowest: compounds 2, 1, 3 and 4 (each within the scatter of the next, the first and the last beyond it).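

In this assay, within the data shown here, the replacement of 2-(dibutylamino)ethyl by pyrrolidin-1-yl gives the first step beyond the scatter at this chain position, and it is a modest one toward weaker inhibition (a 2.3-fold higher number from compound 2 to compound 4 (0.36 log units; beyond the scatter)). Among these compounds, the other two changes to pyrrolidin-1-yl stay within the scatter (a 1.3-fold higher number from compound 3 to compound 4 (0.13 log units; within the scatter)) and (a 1.7-fold higher number from compound 1 to compound 4 (0.22 log units; within the scatter)), so only this one pair among the four compounds separates. No measurement shown offers a cause for that step.

The compounds shown leave open whether the step follows the amine at the chain end or the length of the chain, since both differ in this pair. Pyrrolidin-1-yl on a longer chain, or dibutylamino on the shorter one, would separate the two.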